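This account rests on a few compounds, and the source may have more. Where it says the series, first, only, none or still open, it means among the compounds named here.

Measured compounds in this series:

compound 1, `Cc1cccc(CN2CC=C(CCC(=O)NO)C2=O)c1`, in a functional assay on ACHN cells (Homo sapiens) for inhibition, read by sulforhodamine B assay (on this read-out higher numbers stand for weaker inhibition of growth and lower numbers for stronger inhibition of growth), compound 1 gives 3330 nM
compound 2, `Cc1ccc(CN2CC=C(CCC(=O)NO)C2=O)cc1`, in this assay compound 2 gives 3330 nM
compound 3, `Cc1ccc(CCCCN2CC=C(CCC(=O)NO)C2=O)cc1`, in this assay compound 3 gives 3730 nM

Where compound 2 stands: in this assay compound 2 is level with compound 1 at the digits shown, and the two together hold the lowest of the three numbers. The gap from compound 2 to compound 3 is within the scatter, so no order among the three measured compounds can be read from these numbers; they behave as one group.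

Compound 4, `O=C(CCC1=CCN(Cc2ccc(Cl)cc2)C1=O)NO`, is not yet measured in this assay. It differs from compound 2 by chloro in place of methyl on an aromatic carbon. Among the measured compounds shown here, no pair of measured compounds shows this change, so its size cannot be read from the data. What the three measured compounds do show is that changing where the methyl sits, or lengthening the link between the ring and the shared core, leaves the number within the scatter. On that basis the step is expected to be small: a 1.1-fold lower number from compound 2 to compound 4 (0.05 log units; within the scatter) is estimated to lie within the scatter, with at most a slight lean toward a lower number. For compound 4 the estimate is 3000 nM, with a range from 1200 nM to 7500 nM.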

Compound 4, concentration for 50% growth inhibition: 3330 nM
Compound 4: middle estimate off by 1.1-fold (0.05 log units), on the low side; measured number inside the range.
By their numbers in this assay, from the lowest: compounds 1, 2, 4 and 3 (each within the scatter of the next).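

Chloro in place of methyl, on an aromatic carbon para to a large group, is the first exchange of the group itself, and in this assay it gives no change at the digits printed from compound 2 to compound 4 (within the scatter). The earlier compounds shown here all carried methyl and differed only in where it sat or in the length of the link to the shared core, so they could say nothing about the identity of the group; this step shows that, on this read-out, methyl and chloro at this place cannot be told apart. No measurement at hand bears on why the two groups read alike.

From the compounds shown here alone, with only these two groups compared at this carbon, it stays open whether a larger or differently built group, such as methoxy, an amine or a carboxylic acid, would move the number in this assay beyond the scatter. Also open, going by these compounds, is how chloro reads elsewhere on the aromatic ring or on the longer link of compound 3.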